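Urea series: removing the aromatic methyl from compound 2

The source may report more compounds than this note shows. Statements on the series, on what has been measured and on what is new or still open speak of the compounds shown alone.

compound 1 `Cc1cc(NC(=O)Nc2ccccc2Cl)ccc1OCc1nc2ccccc2s1` — 680 nM
compound 2 `Cc1cc(NC(=O)Nc2cccc(Cl)c2)ccc1OCc1nc2ccccc2s1` — 2090 nM
compound 3 `Cc1cc(NC(=O)Nc2ccc(Cl)cc2)ccc1OCc1nc2ccccc2s1` — a limit, > 10000 nM

In an assay on isolated protein for inhibition of Polyunsaturated fatty acid 5-lipoxygenase (Homo sapiens), read by HPLC, with a stated time of 10 min (on this read-out higher numbers stand for weaker inhibition and lower numbers for stronger inhibition), compound 1 gives 680 nM and compound 2 gives 2090 nM. Compound 3 reaches only the assay limit, > 10000 nM, which is the limit of > 10000 nM in this assay, at which 1 of the 3 values shown sits. Of the two numbers compound 2 holds the higher, the step being a 3.1-fold higher number from compound 1 to compound 2 (0.49 log units; beyond the scatter); the remaining steps, an at least 14-fold higher number from compound 1 to compound 3 (1.16 log units; beyond the scatter) and an at least 4.7-fold higher number from compound 2 to compound 3 (0.67 log units; beyond the scatter), run into the limit. Compound 4 `O=C(Nc1ccc(OCc2nc3ccccc3s2)cc1)Nc1cccc(Cl)c1` differs from compound 2 by hydrogen in place of methyl on an aromatic carbon. Among the compounds with values here, none of the measured steps touches this methyl; all three move the chlorine among the 2-chlorophenyl, 3-chlorophenyl and 4-chlorophenyl groups on the amide-type nitrogen, and compound 2 and compound 4 share the 3-chlorophenyl. Within the data shown here, with no step bearing on the change, compound 4 is expected in this assay to give a number close to that of compound 2, a 1.0-fold lower number from compound 2 to compound 4 (0.02 log units; within the scatter), not beyond the scatter. Compound 4 is estimated at 2000 nM, range 700 nM to 6000 nM.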

Compound 4, half-maximal inhibitory concentration: 170 nM
Estimate against measurement, compound 4: 12-fold (1.07 log units) above; measured number outside the range, below it.
By their numbers in this assay, from the lowest: compound 4; then compound 1; then compound 2. At a limit, above all of these: compound 3.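

In this assay, hydrogen in place of methyl on the aromatic carbon gives a 12-fold lower number from compound 2 to compound 4 (1.09 log units; beyond the scatter), so this position matters to the series even though the change removes only one heavy atom. The earlier steps shown here moved only the chlorine, whereas this one shows that the other aromatic ring of the urea also shifts the number. Nothing measured here gives a cause for this step.

The change is shown only with the 3-chlorophenyl, so its effect with the 2-chlorophenyl or 4-chlorophenyl stays open. Also open, as far as these compounds go, is how an ethyl, methoxy or fluorine would compare at this carbon.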